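Swapping benzofuran for furan on an unresponsive nucleoside series

This account rests on a few compounds, and the source may have more. Where it says the series, first, only, none or still open, it means among the compounds named here.

Measured compounds in a functional assay on HepG2 cells (Homo sapiens) for antiproliferative activity, read by XTT assay, with a stated time of 72 h; on this read-out lower numbers stand for stronger inhibition and higher numbers for weaker inhibition:
- compound 1 `Nc1nc(N)c2c(-c3cc4ccccc4o3)cn([C@@H]3O[C@H](CO)[C@@H](O)[C@H]3O)c2n1` gives > 20000 nM, a limit of the assay
- compound 2 `Cc1nc(N)c2c(-c3cc4ccccc4o3)cn([C@@H]3O[C@H](CO)[C@@H](O)[C@H]3O)c2n1` gives > 20000 nM, also a limit
- compound 3 `CNc1ncnc2c1c(-c1cc3ccccc3o1)cn2[C@@H]1O[C@H](CO)[C@@H](O)[C@H]1O` gives > 20000 nM, again a limit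

Compound 2 therefore stands at the limit, as do both other compounds; (the limit of > 20000 nM in this assay, at which 3 of the 3 values shown sit). Within the data shown here, the only step between measured compounds, a step that the two limits leave unreadable from compound 1 to compound 2, is thus not readable in size. Compound 4 `Cc1nc(N)c2c(-c3ccoc3)cn([C@@H]3O[C@H](CO)[C@@H](O)[C@H]3O)c2n1` differs from compound 2 by furan-3-yl in place of 1-benzofuran-2-yl on an aromatic carbon. Among the measured compounds shown here, no measured step bears on this change, so the expectation rests only on the unreadable starting point. The step from compound 2 to compound 4 is expected to be a number no higher from compound 2 to compound 4 (the limit leaves the size open), with no direction known. Compound 4 is expected to give 20000 nM, in a range from 6000 nM to 60000 nM, most likely again as a limit.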

Compound 4, half-maximal inhibitory concentration: > 20000 nM
Compound 4: only a limit was reported; the forecaster's own chance of this, stated with the estimate: 85%; the middle value sits exactly at the limit.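

Compound 2 and compound 4 both stand at a limit of the assay rather than at a number, so no step between them can be read: the limit of > 20000 nM in this assay, at which 4 of the 4 values shown sit.

The compounds shown leave open whether furan-3-yl or 1-benzofuran-2-yl changes the result at all in this assay.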